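From a ring to a chain on the amide nitrogen

The compounds below may be only part of what the source reports. "The series", "measured", "known", "first", "only" and "open" are said of these compounds alone.

In an ADME assay on Vero cells (Chlorocebus sabaeus) for cytotoxicity, read by neutral red uptake, with a stated time of 3 days (a lower number here means that less compound is tolerated, a higher number that more compound is tolerated), compound 3 `Cc1cc(C(=O)NC2CCN(C)C2)c2cnn(C(C)C)c2n1` gives > 300000 nM, which is a limit of the assay and not a number.

Two related compounds give numbers in this assay. Compound 1 `CC(C)n1ncc2c(C(=O)NC3CCN(C)C3)cc(C3CC3)nc21` gives 33800 nM and compound 2 `CC(C)n1ncc2c(C(=O)NCCN(C)C)cc(C(C)(C)C)nc21` gives 34400 nM, values within the scatter of each other.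

The next compound to be measured is compound 4 `CNCCNC(=O)c1cc(C)nc2c1cnn2C(C)C`, and the change is 2-(methylamino)ethyl in place of 1-methylpyrrolidin-3-yl on an amide-type nitrogen. It places 2-(methylamino)ethyl in place of 1-methylpyrrolidin-3-yl on an amide-type nitrogen.

Within the data shown here, the only measured step near this one is an at least 8.8-fold higher number from compound 1 to compound 3 (0.94 log units; beyond the scatter). That step, methyl in place of cyclopropyl on an aromatic carbon, lies at a different place from the present change, and compound 4 keeps the methyl of compound 3. Among the measured compounds shown here, no measured step isolates the change on the amide nitrogen.

The expected step is small, and any shift would be downward: an at least 1.2-fold lower number from compound 3 to compound 4 (0.07 log units; that floor lies within the scatter). The estimate for compound 4 is 250000 nM, with an expected range of 100000 nM to 300000 nM.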

Compound 4, half-maximal cytotoxic concentration: > 300000 nM
Compound 4: only a limit was reported; the forecaster's own chance of this, stated with the estimate: 55%; at least 1.2-fold (0.07 log units) between middle value and limit.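

Compound 3 and compound 4 both end at a limit of the assay and not at a number in this assay, so no step between them can be read: the limit of > 300000 nM in this assay, at which 2 of the 4 values shown sit.

The compounds shown leave open whether 2-(methylamino)ethyl in place of 1-methylpyrrolidin-3-yl on an amide-type nitrogen shifts the number in this assay at all.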